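The source may report more compounds than this note shows. Statements on the series, on what has been measured and on what is new or still open speak of the compounds shown alone.

All the compounds here differ only in one aromatic group on the shared core. In a functional assay on MCF7 cells (Homo sapiens) for inhibition, read by CCK-8 assay, with a stated time of 48 h (on this read-out lower numbers stand for stronger inhibition and higher numbers for weaker inhibition), compound 1 `COc1cc(-c2ccnc3cc(-c4ccc(F)cc4)nn23)cc(OC)c1OC`, carrying 4-fluorophenyl, gives 1280 nM. Compound 2 `COc1cc(-c2ccnc3cc(-c4c[nH]c5ccccc45)nn23)cc(OC)c1OC`, carrying 1H-indol-3-yl, gives 85 nM, and compound 3 `COc1cc(-c2ccnc3cc(-c4ccc(N(C)C)cc4)nn23)cc(OC)c1OC`, carrying 4-(dimethylamino)phenyl, gives 44 nM. The gap between these last two is a 1.9-fold lower number from compound 2 to compound 3 (0.29 log units; within the scatter), so they cannot be told apart. Both stand far from the first compound, with a 15-fold lower number from compound 1 to compound 2 (1.18 log units; beyond the scatter) and a 29-fold lower number from compound 1 to compound 3 (1.46 log units; beyond the scatter).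

Within the data shown here, compound 4 `COc1ccc(-c2cc3nccc(-c4cc(OC)c(OC)c(OC)c4)n3n2)cc1F` keeps the core of compound 3 and changes only this group: 3-fluoro-4-methoxyphenyl in place of 4-(dimethylamino)phenyl on an aromatic carbon. The dimethylamino group is lost, and a fluoro and a methoxy arrive on the phenyl ring. The most relevant measured step is a 29-fold lower number from compound 1 to compound 3 (1.46 log units; beyond the scatter), where dimethylamino took the place of fluoro. Compound 4 partly walks that step back, so a higher number is expected in this assay. However, no measured compound carries methoxy on this phenyl ring, and its fluoro sits elsewhere on the ring than in compound 1, so the full return is not assumed. The estimated change is a 6.8-fold higher number from compound 3 to compound 4 (0.83 log units; beyond the scatter), large but short of the whole earlier step. For compound 4 the expected value is 300 nM, with an estimated range from 80 nM to 1000 nM.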

Compound 4, half-maximal inhibitory concentration: 183 nM
Beside the measured number, compound 4's estimate is 1.6-fold (0.21 log units) above it, and the stated range covers the measured number.
By their numbers in this assay, from the lowest: compounds 3 and 2 (each within the scatter of the next); then compound 4; then compound 1.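

In this assay this position now shows a middle level: there is a 4.2-fold higher number from compound 3 to compound 4 (0.62 log units; beyond the scatter) and also a 2.2-fold higher number from compound 2 to compound 4 (0.33 log units; beyond the scatter) while, on the other side, there is a 7.0-fold lower number from compound 1 to compound 4 (0.84 log units; beyond the scatter) and so 3-fluoro-4-methoxyphenyl stands clearly apart from 4-fluorophenyl. Compound 4 has no nitrogen in this group, so a nitrogen there, as in the 4-(dimethylamino)phenyl of compound 3 and the 1H-indol-3-yl of compound 2, is not needed for a number well under that of compound 1. The groups of compound 3 and compound 4 have the same heavy-atom count and the same carbon-only six-membered aromatic ring, yet their numbers lie beyond the scatter of each other, so that count alone does not set the result.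

Nothing among the data explains why these groups differ. From the compounds shown here alone, it stays open whether the methoxy or the fluoro of compound 4 accounts for its step from compound 1, and how 4-methoxyphenyl alone, a morpholine or a carboxylic acid on the phenyl ring would fare at this position.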